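Swapping pyrrolidin-1-yl for dimethylamino on a ring carbon

This account rests on a few compounds, and the source may have more. Where it says the series, first, only, none or still open, it means among the compounds named here.

Measured in an ADME assay on L6 cells (Rattus norvegicus) for cytotoxicity, with a stated time of 72 h; a lower number here means a stronger inhibitor, a higher number a weaker inhibitor:
- compound 1 `CN(C)C12CC(OC(=O)CN3CCCC3)C(C(c3ccccc3)C1)C(c1ccccc1)C2`: 32700 nM
- compound 2 `CN(C)C12CC(OC(=O)C(C)(C)C)C(C(c3ccccc3)C1)C(c1ccccc1)C2`: 5060 nM
- compound 3 `OC1CC2(N3CCCC3)CC(c3ccccc3)C1C(c1ccccc1)C2`: 26800 nM

Compound 3 lies within the scatter of compound 1, and its value is higher than that of compound 2. Compound 4 `CN(C)C12CC(O)C(C(c3ccccc3)C1)C(c1ccccc1)C2` has dimethylamino in place of pyrrolidin-1-yl on a saturated ring carbon. For the measured compounds named here, no measured step makes this swap. The only one, a 6.5-fold lower number from compound 1 to compound 2 (0.81 log units; beyond the scatter), is modest but concerns a carbonyl carbon, so it bears only weakly. Compound 1 already carries dimethylamino and gives 32700 nM, while compound 2 also carries it and gives 5060 nM, so the range stays wide. The expected change in this assay is a 1.0-fold higher number from compound 3 to compound 4 (0.02 log units; within the scatter), none beyond the scatter. For compound 4 the estimated value is 28000 nM, with an expected range of 10000 nM to 70000 nM.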

Compound 4, half-maximal inhibitory concentration: 133000 nM
Compound 4: the middle estimate sits 4.8-fold (0.68 log units) below what was measured; measured number above the stated range.
By their numbers in this assay, from the lowest: compound 2; then compounds 3 and 1 (each within the scatter of the next); then compound 4.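

In this assay the swap on the saturated ring carbon is not neutral: dimethylamino in place of pyrrolidin-1-yl gives a 5.0-fold higher number from compound 3 to compound 4 (0.70 log units; beyond the scatter) with the hydroxy group left free. Removing the group on the oxygen also counts, with a 26-fold higher number from compound 2 to compound 4 (1.42 log units; beyond the scatter) on losing (tert-butyl)carbonyl and a 4.1-fold higher number from compound 1 to compound 4 (0.61 log units; beyond the scatter) on losing ((pyrrolidin-1-yl)methyl)carbonyl, so compound 4 has the highest number of the four.

From the compounds shown here alone, how piperidin-1-yl or diethylamino on that ring carbon would compare stays open, as does the same swap with a carbonyl group on the oxygen. Nothing available explains why these numbers move.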